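Moving the bromine around the ring of compound 2

This account rests on a few compounds, and the source may have more. Where it says the series, first, only, none or still open, it means among the compounds named here.

Measured so far:
compound 1, `Cc1ccc(C(=O)/C=C/c2cccc(OCc3ccccc3)c2)cc1`, 20500 nM
compound 2, `O=C(/C=C/c1cccc(OCc2ccccc2)c1)c1ccccc1Br`, 2500 nM

In a functional assay on A2780 cells (Homo sapiens) for cytotoxicity, read by MTT assay, with a stated time of 68 h (on this read-out lower numbers stand for stronger inhibition and higher numbers for weaker inhibition), compound 1 gives 20500 nM, while compound 2 gives 2500 nM. Among the compounds with values here, compound 2 thus has the lowest number of the two, and the only step measured so far, an 8.2-fold lower number from compound 1 to compound 2 (0.91 log units; beyond the scatter), is the change of the group on the carbonyl carbon from 4-methylphenyl to 2-bromophenyl.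

Compound 3, `O=C(/C=C/c1cccc(OCc2ccccc2)c1)c1cccc(Br)c1`, keeps every atom of compound 2 but joins them differently: 3-bromophenyl in place of 2-bromophenyl on a carbonyl carbon. Within the data shown here, no measured pair shows what shifting the bromine within the ring does; the one step available, an 8.2-fold lower number from compound 1 to compound 2 (0.91 log units; beyond the scatter), exchanges both the substituent and its place at once, so it only suggests that the group on the carbonyl carbon matters. A change smaller than that step, in either direction, is therefore expected, with a slightly higher number more likely than a lower one, as compound 2 already holds the low end. Compound 3 is estimated at 4000 nM, within 1500 nM to 12000 nM, a step of a 1.6-fold higher number from compound 2 to compound 3 (0.20 log units; within the scatter).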

Compound 3, half-maximal inhibitory concentration: 6300 nM
For compound 3 the middle estimate is 1.6-fold (0.20 log units) below the measured one, and the stated range covers the measured number.
By their numbers in this assay, from the lowest: compound 2; then compound 3; then compound 1.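

Compound 3 separates the place of the bromine from its presence, which the earlier step could not do: in this assay replacing 2-bromophenyl with 3-bromophenyl on the carbonyl carbon gives a 2.5-fold higher number from compound 2 to compound 3 (0.40 log units; beyond the scatter) with no atom gained or lost, so the place on the ring alone changes the number. Bromine in the new place still keeps part of the earlier drop, as replacing 4-methylphenyl with 3-bromophenyl gives a 3.3-fold lower number from compound 1 to compound 3 (0.51 log units; beyond the scatter) and leaves compound 3 between the other two compounds. Nothing available here explains why the place of the bromine changes the number.

The compounds shown leave open how 4-bromophenyl would compare, which would also set bromine against methyl at one and the same place on the ring. They also leave open whether the lower number of compound 2 belongs to bromine itself or would carry over to another group in the same place, such as 2-chlorophenyl, 2-methylphenyl or 2-methoxyphenyl.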